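Chloro in place of hydrogen on compound 3

This account rests on a few compounds, and the source may have more. Where it says the series, first, only, none or still open, it means among the compounds named here.

In an ADME assay on microsomes from liver (Canis lupus familiaris) for metabolic stability, with a stated time of 10 min (on this read-out lower numbers stand for a less stable compound and higher numbers for a more stable compound), compound 3 `FC(F)(F)c1ccccc1-c1ccc2[nH]c(C3=NOC4(CCOCC4)C3)nc2c1` gives 83%, the second highest of three numbers. Compound 2 `FC(F)(F)c1ccccc1-c1cc(Cl)c2[nH]c(C3=NOC4(CCCCC4)C3)nc2c1` stands higher at 100%, and compound 1 `FC(F)(F)c1ccccc1-c1ccc2[nH]c(C3=NCC4(CCCCC4)N3)nc2c1` stands lower at 36%, both beyond the scatter. Compound 4 `FC(F)(F)c1ccccc1-c1cc(Cl)c2[nH]c(C3=NOC4(CCOCC4)C3)nc2c1` differs from compound 3 by chloro in place of hydrogen on an aromatic carbon. Compound 2 also carries chloro and reads 100%, but it differs from compound 3 in more than one place, so it offers only loose guidance. A small rise is expected, estimated as a number 9 percentage points higher from compound 3 to compound 4 (within the scatter). Compound 4 is estimated at 92%, with an expected range of 78% to 100%.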

Compound 4, percent of the compound remaining: 81%
The estimate for compound 4 lay 11 percentage points above the measured number; low and high end bracket the measured number.
By their numbers in this assay, from the lowest: compound 1; then compounds 4 and 3 (each within the scatter of the next); then compound 2.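

Placed ortho to a fused ring, chloro in place of hydrogen gives a number 2 percentage points lower from compound 3 to compound 4 (within the scatter) in this assay, so on this scaffold the swap shows no effect beyond the scatter. With chloro held constant, the step of a number 19 percentage points lower from compound 2 to compound 4 (beyond the scatter) shows that the group with a six-membered non-aromatic ring with 1 hetero atom reads differently from the one with a six-membered ring of carbon only. Nothing available explains either step. From the compounds shown here alone, whether a methoxy group or a nitrile on this carbon would read like chloro remains open.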